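This account rests on a few compounds, and the source may have more. Where it says the series, first, only, none or still open, it means among the compounds named here.

In a functional assay for inhibition of transient receptor potential cation channel subfamily V member 1 (Homo sapiens), read by fluorescence and calcium flux (a higher number here means a weaker inhibitor, a lower number a stronger inhibitor), compound 2 `CCc1nc(O)c2cc(-c3ccc(Cl)cc3)c(C(C)C)cc2n1` gives only a limit, > 1000 nM. Compound 1 `Cc1nc(O)c2cc(-c3ccc(Cl)c(OCC(=O)O)c3)c(C(C)C)cc2n1` likewise reaches only a limit, > 1000 nM. Both shown values sit at the same point: the limit of > 1000 nM in this assay, at which 2 of the 2 values shown sit. Compound 3 `CC(C)c1cc2nc(N)nc(O)c2cc1-c1ccc(Cl)cc1` differs from compound 2 by amino in place of ethyl on an aromatic carbon. No step between measured compounds is known here, and the two shown values do not separate a stronger from a weaker inhibitor. Compound 3 is therefore expected to remain weak, most probably again reported as a limit, with an estimated step that the limit leaves unreadable from compound 2 to compound 3. For compound 3 the estimate in this assay is 3000 nM, within a range from 800 nM to 15000 nM.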

Compound 3, half-maximal inhibitory concentration: 133 nM
For compound 3 the middle estimate is 23-fold (1.35 log units) above the measured one; the measured number lies below the stated range.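

In this assay, the place between two ring nitrogen atoms proves able to shift the read-out: amino in place of ethyl gives an at least 7.5-fold lower number from compound 2 to compound 3 (0.87 log units; beyond the scatter), the only step shown that separates a stronger from a weaker inhibitor. Its full size cannot be read because compound 2 gives only a limit: the limit of > 1000 nM in this assay, at which 2 of the 3 values shown sit.

From the compounds shown here alone, whether a methylamino or dimethylamino group at this place would hold the lower number stays open. So does whether amino would produce the same shift on the other compounds in the series, such as compound 1.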